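This account rests on a few compounds, and the source may have more. Where it says the series, first, only, none or still open, it means among the compounds named here.

Measured in a functional assay on MIA PaCa-2 cells (Homo sapiens) for cytotoxicity, read by fluorescence, with a stated time of 48 h; on this read-out lower numbers stand for an effect already at smaller amounts and higher numbers for an effect only at larger amounts of compound:
Compound 1 `CC(C)=CCC/C(C)=C/CC/C(C)=C/CSC[C@H](NC(=O)CCCCCN1CCN(C)CC1)C(=O)NC1CCCCCC1`: 2700 nM
Compound 2 `CC(C)=CCC/C(C)=C/CC/C(C)=C/CSC[C@H](NC(=O)CCCCCN1CCN(C)CC1)C(=O)NC1CC1`: 10400 nM
Compound 3 `CC(C)=CCC/C(C)=C/CC/C(C)=C/CSC[C@H](NC(=O)CCCCCN1CCN(C)CC1)C(=O)N1CCCC1`: 6000 nM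

Compound 3 stands close to compound 2, with a 1.7-fold lower number from compound 2 to compound 3 (0.24 log units; within the scatter), whereas compound 1 has the lowest number, with a 2.2-fold higher number from compound 1 to compound 3 (0.35 log units; beyond the scatter). Compound 4 `CC(C)=CCC/C(C)=C/CC/C(C)=C/CSC[C@H](NC(=O)CCCCCN1CCN(C)CC1)C(=O)NC1CCCCCCC1` carries cyclooctylamino in place of pyrrolidin-1-yl on a carbonyl carbon. Within the data shown here, no measured compound carries cyclooctylamino. The closest comparison is compound 1, so the modest step of a 2.2-fold higher number from compound 1 to compound 3 (0.35 log units; beyond the scatter) bears most directly, read in reverse. The step of a 3.9-fold higher number from compound 1 to compound 2 (0.59 log units; beyond the scatter) also leaves compound 1 with the lower number. In this assay, the expected change is modest and downward, a 2.4-fold lower number from compound 3 to compound 4 (0.38 log units; beyond the scatter). The estimate for compound 4 is 2500 nM, with an expected range of 1200 nM to 5200 nM.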

Compound 4, half-maximal effective concentration: 2500 nM
Compound 4: middle estimate and measured number agree at the digits printed; the measured number falls inside the stated range.
By their numbers in this assay, from the lowest: compounds 4 and 1 (each within the scatter of the next); then compounds 3 and 2 (each within the scatter of the next).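

In this assay, cyclooctyl and cycloheptyl on the amide-type nitrogen cannot be told apart (a 1.1-fold lower number from compound 1 to compound 4 (0.03 log units; within the scatter)), so the lower numbers seen with cycloheptyl hold for a still larger ring. Cyclooctyl keeps its distance from the small cyclopropyl ring (a 4.2-fold lower number from compound 2 to compound 4 (0.62 log units; beyond the scatter)) and from pyrrolidin-1-yl on the carbonyl carbon (a 2.4-fold lower number from compound 3 to compound 4 (0.38 log units; beyond the scatter)). Nothing measured here explains these steps. Pyrrolidin-1-yl and cyclooctylamino differ in both ring and amide hydrogen, and the compounds shown do not separate the two. On these data alone, how a straight hexyl chain or a phenyl ring on that nitrogen would compare also remains open.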